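A few compounds are considered here, and "the series" means these few. Any claim that something is new, unique, unknown or untested is made for them only; others in the source may bear on it.

Compound 1 `CC(C)Cn1nc(C(=O)N[C@H]2COc3ccccc3N(C)C2=S)nc1Cc1ccccc1`: 1230 nM in a functional assay on HT-29 cells (Homo sapiens) for inhibition, read by luminescence and CellTiter-Glo, with a stated time of 24 h; on this read-out lower numbers stand for an effect already at smaller amounts and higher numbers for an effect only at larger amounts of compound
Compound 2 `CN1C(=S)[C@@H](NC(=O)c2nc(Cc3ccccc3)n(CCCF)n2)COc2ccccc21`: 4760 nM in this assay
Compound 3 `CN1C(=S)[C@@H](NC(=O)c2nc(Cc3ccccc3)n(C3CCC3)n2)COc2ccccc21`: 181 nM in this assay

Among these three, compound 2 carries the highest number, so it needs the largest amount of compound for its effect. Its neighbours are set apart from it by a 3.9-fold higher number from compound 1 to compound 2 (0.59 log units; beyond the scatter) and by a 26-fold lower number from compound 2 to compound 3 (1.42 log units; beyond the scatter), and the two chains also differ from the ring by a 6.8-fold lower number from compound 1 to compound 3 (0.83 log units; beyond the scatter).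

The new compound 4 `CN1C(=S)[C@@H](NC(=O)c2nc(Cc3ccccc3)n(C3CCNC3)n2)COc2ccccc21` differs from compound 2 in one place: pyrrolidin-3-yl in place of 3-fluoropropyl on an aromatic nitrogen. The step that bears most on this is a 26-fold lower number from compound 2 to compound 3 (1.42 log units; beyond the scatter), where a ring took the place of a chain on the same aromatic nitrogen, and a 6.8-fold lower number from compound 1 to compound 3 (0.83 log units; beyond the scatter) points the same way. The ring entering here is a five-membered non-aromatic ring rather than cyclobutyl, so the gain is expected to be smaller than that seen with compound 3. This change is expected to give a step of a 5.3-fold lower number from compound 2 to compound 4 (0.72 log units; beyond the scatter). Compound 4 is therefore expected to give 900 nM, within a range from 150 nM to 4500 nM.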

Compound 4, half-maximal effective concentration: 1070 nM
The estimate for compound 4 lay 1.2-fold (0.08 log units) below the measured number, within the range that was stated.
By their numbers in this assay, from the lowest: compound 3; then compounds 4 and 1 (each within the scatter of the next); then compound 2.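

In this assay the swap to pyrrolidin-3-yl gives a 4.4-fold lower number from compound 2 to compound 4 (0.65 log units; beyond the scatter) and so again improves on 3-fluoropropyl, as cyclobutyl did in compound 3. The two rings are not interchangeable at this aromatic nitrogen, though: a 5.9-fold higher number from compound 3 to compound 4 (0.77 log units; beyond the scatter) shows that the kind of ring matters, not just the presence of one. A ring also does not always beat a chain here, since a 1.1-fold lower number from compound 1 to compound 4 (0.06 log units; within the scatter) leaves compound 4 and the isobutyl compound 1 indistinguishable.

Pyrrolidin-3-yl differs from cyclobutyl in both ring size and its ring nitrogen, so cyclopentyl, a five-membered ring of carbon only, would be needed to tell these two changes apart. Nothing available explains why these groups differ as they do.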